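Halogen Swap from Compound 3 to Compound 4

The compounds below may be only part of what the source reports. "The series", "measured", "known", "first", "only" and "open" are said of these compounds alone.

Within the data shown here, compound 3 `C=CC(=O)Nc1cccc(NC(=O)CSc2nc(Nc3cccc(Cl)c3)c3ccccc3n2)c1` gives 7830 nM in a functional assay on MGC-803 cells (Homo sapiens) for inhibition, read by MTT assay, with a stated time of 72 h (a lower number here means a stronger inhibitor, a higher number a weaker inhibitor), the second highest of the three numbers so far: compound 2 `C=CC(=O)Nc1cccc(NC(=O)CSc2nc(Nc3cccc(F)c3)c3ccccc3n2)c1` gives 6250 nM, within the scatter of compound 3, while compound 1 `O=C(CSc1nc(Nc2ccccc2)c2ccccc2n1)Nc1ccc(Br)cc1` gives 19300 nM, beyond it. Compound 4 `C=CC(=O)Nc1cccc(NC(=O)CSc2nc(Nc3ccc(Br)cc3)c3ccccc3n2)c1` differs from compound 3 by 4-bromophenyl in place of 3-chlorophenyl on a nitrogen on an aromatic ring, read one bond further out as (3-chlorophenyl)amino to (4-bromophenyl)amino. Among the measured compounds shown here, the only measured step on this ring is a 1.3-fold higher number from compound 2 to compound 3 (0.10 log units; within the scatter), a halogen-for-halogen change that stayed within the scatter. Compound 1 also carries 4-bromophenyl but differs from compound 3 at a second position, so its number bears only loosely. Compound 4 is therefore expected at 8500 nM, with a range of 4000 nM to 18000 nM. The expected step of a 1.1-fold higher number from compound 3 to compound 4 (0.04 log units; within the scatter) is estimated to remain within the scatter.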

Compound 4, half-maximal inhibitory concentration: 11500 nM
Beside the measured number, compound 4's estimate is 1.4-fold (0.13 log units) below it; the range from low to high includes it.
By their numbers in this assay, from the lowest: compounds 2, 3, 4 and 1 (each within the scatter of the next, the first and the last beyond it).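

In this assay the change on the nitrogen gives a 1.5-fold higher number from compound 3 to compound 4 (0.17 log units; within the scatter) and, set against the fluoro analogue, a 1.8-fold higher number from compound 2 to compound 4 (0.26 log units; within the scatter) as well. Earlier only 3-fluorophenyl and 3-chlorophenyl could be compared, whereas 4-bromophenyl now changes the halogen and its ring position together, and none of the three groups is separated from the others. From the compounds shown here alone, whether the halogen or its ring position matters more stays open, and 3-bromophenyl would separate the two. Going by these compounds, a group without halogen on this ring, such as methoxy or an amine, is also open. No evidence bears on the cause of these numbers.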